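Shortening the Hydroxycarbamoyl Chain of Compound 1

A few compounds are considered here, and "the series" means these few. Any claim that something is new, unique, unknown or untested is made for them only; others in the source may bear on it.

Of the compounds shown here, three have been measured in a functional assay on PC-3 cells (Homo sapiens) for antiproliferative activity, read by sulforhodamine B assay, with a stated time of 48 h; on this read-out lower numbers stand for stronger inhibition of growth and higher numbers for weaker inhibition of growth. Compound 1 `CC(C)CCc1c(OCCCCCC(=O)NO)ccc2ccc(=O)oc12` gives 740 nM, the lower of the two true numbers available. Compound 3 `CC(C)CCc1c(OCCCCCCCC(=O)NO)ccc(CCC(=O)NO)c1O` gives 1730 nM, and this gap lies beyond the usual scatter. Compound 2 `CC(C)CCc1c(OCCCCCCC(=O)NO)ccc2c1OC(=O)CC2` gives > 30000 nM, which is a limit of the assay and not a number.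

Compound 4 `CC(C)CCc1c(OCCCCC(=O)NO)ccc2ccc(=O)oc12` has not yet been measured. It differs from compound 1 in one place: hydroxycarbamoyl in place of (hydroxycarbamoyl)methyl on a saturated chain carbon, four bonds along the chain from an oxygen on an aromatic ring. In words, hydroxycarbamoyl stands in place of (hydroxycarbamoyl)methyl on a saturated chain carbon, four bonds along the chain from an oxygen on an aromatic ring. The chain therefore becomes shorter, while the rest of the structure stays the same.

Going by the values given here, no measured pair differs by a single change, so the size of this step cannot be read directly from the data. Among the compounds with values here, with compound 1 at 740 nM, the best number so far, a moderate rise in this assay is expected, probably beyond the scatter. The estimated step is a 2.0-fold higher number from compound 1 to compound 4 (0.31 log units; beyond the scatter). Compound 4 is expected to give 1500 nM, with an estimated range from 500 nM to 5000 nM.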

Compound 4, concentration for 50% growth inhibition: 1940 nM
Beside the measured number, compound 4's estimate is 1.3-fold (0.11 log units) below it; measured number inside the range.
By their numbers in this assay, from the lowest: compound 1; then compounds 3 and 4 (each within the scatter of the next). At a limit, above all of these: compound 2.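

In this assay, going by these compounds alone, this is the first step that can be read directly, since compound 1 and compound 4 differ in one place only: hydroxycarbamoyl in place of (hydroxycarbamoyl)methyl on a saturated chain carbon, four bonds along the chain from an oxygen on an aromatic ring. With the shared core and the hydroxycarbamoyl end group unchanged, removing one chain carbon gives a 2.6-fold higher number from compound 1 to compound 4 (0.42 log units; beyond the scatter). The length of this chain therefore affects growth inhibition, although the step is modest and the shorter compound keeps a measurable number; nothing shown here explains why the number moves with this change.

On these data alone, it remains open whether a longer chain than that of compound 1 would lower the number further or raise it, so the best length for this chain cannot yet be set. As far as these compounds go, it is also open how much growth inhibition would remain with a carboxylic acid or a primary amide in place of the hydroxycarbamoyl group at the end of the chain.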